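The compounds below may be only part of what the source reports. "The series", "measured", "known", "first", "only" and "open" are said of these compounds alone.

Measured in a functional assay on the whole organism for inhibition, with Rattus norvegicus as the target, read by paw edema, with stated times of 30 min and 2 h, at a dose of 0.28 mmol/kg by the oral route; a lower number here means less inhibition, a higher number more inhibition at the dose given (going by the name of the read-out):

Compound 1 `CNC(=O)c1nc(-c2cc(OC)c(OC)c(OC)c2)n(-c2ccc(OC)cc2)n1`: 74%
Compound 2 `COc1ccc(-n2nc(C(=O)Nc3cccc(F)c3)nc2-c2cc(OC)c(OC)c(OC)c2)cc1`: 67%
Compound 3 `COc1ccc(-n2nc(C(=O)Nc3ccc(C(F)(F)F)cc3)nc2-c2cc(OC)c(OC)c(OC)c2)cc1`: 55%

Compound 3 gives the lowest of the three numbers in this assay. Its nearest neighbour is compound 2, and the step of a number 12 percentage points lower from compound 2 to compound 3 (beyond the scatter) is beyond the scatter; the step of a number 19 percentage points lower from compound 1 to compound 3 (beyond the scatter) is larger still. The step of a number 7 percentage points lower from compound 1 to compound 2 (within the scatter), by contrast, lies within the scatter.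

Compound 4 `COc1ccc(-n2nc(C(=O)Nc3ccc(C(=O)O)cc3)nc2-c2cc(OC)c(OC)c(OC)c2)cc1` differs from compound 3 by carboxy in place of trifluoromethyl on an aromatic carbon. For the measured compounds named here, none of the measured steps exchanges one substituent on this phenyl ring for another; all three measured steps alter what sits on the amide-type nitrogen, and those steps range from within the scatter to modest. Going by the values given here, with no direct precedent, the change from trifluoromethyl to carboxy is expected to leave compound 4 near compound 3 or somewhat between compound 3 and compound 2, without a step clearly beyond the scatter. The estimated step is a number 5 percentage points higher from compound 3 to compound 4 (within the scatter). For compound 4 the expected value in this assay is 60%, in a range from 45% to 75%.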

Compound 4, a percentage reported as inhibition, in the whole organism at one dose (the size of the read-out at that dose, not a potency): 57%
Compound 4: the middle estimate sits 3 percentage points above what was measured; low and high end bracket the measured number.
By their numbers in this assay, from the lowest: compounds 3, 4, 2 and 1 (each within the scatter of the next, the first and the last beyond it).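

In this assay, for the compounds shown here, the step of a number 2 percentage points higher from compound 3 to compound 4 (within the scatter) is the first exchange of one substituent for another on this phenyl ring, and it shows that carboxy can replace trifluoromethyl on this aromatic carbon, para to a large group, without a shift beyond the scatter. The amide-nitrogen comparisons partly follow the same picture: a number 17 percentage points lower from compound 1 to compound 4 (beyond the scatter) remains beyond the scatter, but a number 10 percentage points lower from compound 2 to compound 4 (within the scatter) stays within it, whereas a number 12 percentage points lower from compound 2 to compound 3 (beyond the scatter) did not. Nothing given here explains why these two groups read so alike.

Going by these compounds, whether an amine, a nitrile or a methyl ester on the same carbon would also leave this assay within the scatter remains open. Because each compound is shown at a single dose, the results also leave open how the compounds compare in potency.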